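The source may report more compounds than this note shows. Statements on the series, on what has been measured and on what is new or still open speak of the compounds shown alone.

Measured in a functional assay on the whole organism (strain Kunming) for inhibition, with Mus musculus as the target, in the writhing test, at a dose of 40 mg/kg by the oral route; a lower number here means less inhibition, a higher number more inhibition at the dose given (going by the name of the read-out):

compound 1 `O=C(Oc1ccc(-c2ccc(F)cc2F)cc1C(=O)O)c1ccccc1`: 7.97%
compound 2 `CCNC(=O)c1cc(-c2ccc(F)cc2F)ccc1OC(C)=O`: 23.9%
compound 3 `CC(=O)Oc1ccc(-c2ccc(F)cc2F)cc1C(=O)NC1CCCCC1`: 15.6%

Compound 2 carries the highest number of the three, but compound 3 sits within the usual scatter of it, so no order between those two can be claimed; only compound 1 lies beyond the scatter below compound 2.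

Compound 4 `CC(=O)Oc1ccc(-c2ccc(F)cc2F)cc1C(=O)Nc1ccccc1` is not yet measured. Against compound 2 the difference is phenyl in place of ethyl on an amide-type nitrogen. For the measured compounds named here, the one measured step that bears on this is the change at the same amide-type nitrogen, ethyl to cyclohexyl, which gave a number 8.3 percentage points lower from compound 2 to compound 3 (within the scatter), a shift that does not leave the scatter. Nothing measured speaks to an aromatic ring at that position, and compound 1, with a benzoyl ester and a free acid instead of the acetate and amide, is not a comparable case.

The expectation is therefore no step beyond the scatter, with a lean slightly downward in line with the cyclohexyl case: the estimated step is a number 5.9 percentage points lower from compound 2 to compound 4 (within the scatter). In this assay compound 4 is estimated at 18%, within a range from 7% to 30%.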

Compound 4, a percentage reported as inhibition, in the whole organism at one dose (the size of the read-out at that dose, not a potency): 8.9%
Estimate against measurement, compound 4: 9.1 percentage points above; the range from low to high includes it.
By their numbers in this assay, from the lowest: compounds 1, 4, 3 and 2 (each within the scatter of the next, the first and the last beyond it).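

At the amide-type nitrogen, phenyl in place of ethyl gives a step in this assay that leaves the scatter, a number 15 percentage points lower from compound 2 to compound 4 (beyond the scatter), whereas the earlier change from ethyl to cyclohexyl at this nitrogen stayed within it. The step of phenyl in place of cyclohexyl, a number 6.7 percentage points lower from compound 3 to compound 4 (within the scatter), is within the scatter, so these two ring-bearing groups cannot be told apart at this position, and the reading is limited to a lower number for phenyl than for ethyl. No measurement on hand explains this step.

Still open, as far as these compounds go, is whether the lower number belongs to the aromatic ring itself or would also appear with other groups on this nitrogen, and a methyl, a longer chain such as butyl or a benzyl group would help to separate those cases. Also open, from the compounds shown here alone, is how the anilino group responds to a methoxy group or an amine on its ring, and whether a free carboxylic acid in place of the amide, with the acetate kept, reads differently from the amides.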